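Notes on the step from compound 2 to compound 3

A few compounds are considered here, and "the series" means these few. Any claim that something is new, unique, unknown or untested is made for them only; others in the source may bear on it.

Measured in an ADME assay on HCT-116 cells (Homo sapiens) for cytotoxicity, read by CellTiter-Glo, with a stated time of 72 h; on this read-out lower numbers stand for stronger inhibition and higher numbers for weaker inhibition:
- compound 1 `Cc1noc(C)c1S(=O)(=O)N1CCC(N2CCC(C)CC2)CC1`: > 10000 nM (a limit)
- compound 2 `CC1CCN(C2CCN(S(=O)(=O)c3ccccc3Br)CC2)CC1`: > 5000 nM (a limit)

Compound 2 stands only at a limit of > 5000 nM, so no number is known for it. Compound 3 `CC1CCN(C2CCN(S(=O)(=O)c3cnc(Cl)s3)CC2)CC1` has not yet been measured in this assay. It carries 2-chloro-1,3-thiazol-5-yl in place of 2-bromophenyl on a sulfonyl sulfur.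

Within the data shown here, the only measured step, a step that the two limits leave unreadable from compound 1 to compound 2, changes the group at the same sulfonyl sulfur. Its size cannot be read, so it offers no size to carry over. With no readable step to draw on, no change beyond the scatter is expected, and another limit is the likeliest report. The expected step is a step that the limit leaves unreadable from compound 2 to compound 3. For compound 3 the estimated value is 6000 nM, with an expected range of 2500 nM to 20000 nM.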

Compound 3, half-maximal inhibitory concentration: > 10000 nM
Compound 3: no number, only a limit; the forecaster's own chance of this, stated with the estimate: 70%; middle value at least 1.6-fold (0.22 log units) from the limit.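

Among these compounds, compound 1, compound 2 and compound 3 all stand only at limits, so no step among them can be read. The compounds shown leave open whether any group on the sulfonyl sulfur gives a measurable number in this assay.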